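A few compounds are considered here, and "the series" means these few. Any claim that something is new, unique, unknown or untested is made for them only; others in the source may bear on it.

Notes on the series. Compound 1 `COc1ccc(CSc2nnc(-c3cc(OC)c(OC)c(OC)c3)n2-c2ccc(OC)cc2)cc1` and compound 2 `COc1ccc(-n2c(SCc3ccc(F)cc3)nnc2-c2cc(OC)c(OC)c(OC)c2)cc1` share a core; compound 3 `COc1ccc(C(=O)CSc2nnc(-c3cc(OC)c(OC)c(OC)c3)n2-c2ccc(N(C)C)cc2)cc1` carries a different core, and the difference between the two cores is not broken down here. In a functional assay on HT-29 cells (Homo sapiens) for inhibition, read by MTT assay, with a stated time of 48 h (on this read-out higher numbers stand for weaker inhibition and lower numbers for stronger inhibition), compound 1 gives only a limit, > 60000 nM, which is the limit of > 60000 nM in this assay, at which 1 of the 3 values shown sits. In this assay compound 2 gives 50700 nM. The step of an at least 1.1-fold lower number from compound 1 to compound 2 (0.07 log units; that floor lies within the scatter) goes with the change (fluoro in place of methoxy on an aromatic carbon). In this assay compound 3 gives 64000 nM, a number that lies within the scatter of the value for compound 2, so no order between the two is read. Among the measured compounds shown here, compound 4 `COc1cc(-c2nnc(SCC(=O)c3ccc(F)cc3)n2-c2ccc(N(C)C)cc2)cc(OC)c1OC` is not yet measured; it differs from compound 3 by fluoro in place of methoxy on an aromatic carbon, the same change as the one from compound 1 to compound 2, at a place described in the same words. The step from compound 3 to compound 4 is expected to be a 1.2-fold lower number from compound 3 to compound 4 (0.07 log units; within the scatter), resting on the earlier step, an at least 1.1-fold lower number from compound 1 to compound 2 (0.07 log units; that floor lies within the scatter), whose floor lay within the scatter. Compound 4 is expected to give 55000 nM in this assay, with a range from 25000 nM to 120000 nM.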

Compound 4, half-maximal inhibitory concentration: 78100 nM
Beside the measured number, compound 4's estimate is 1.4-fold (0.15 log units) below it; measured number inside the range.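

On the core of compound 3, in this assay, fluoro in place of methoxy on an aromatic carbon goes with a 1.2-fold higher number from compound 3 to compound 4 (0.09 log units; within the scatter), so the 4-methoxyphenyl to 4-fluorophenyl change gives no readable step on this core. Set beside the step on the core of compound 1, the two results cannot be told apart: the same change on two cores in this assay, an at least 1.1-fold lower number (0.07 log units; that floor lies within the scatter) from compound 1 to compound 2 and a 1.2-fold higher number (0.09 log units; within the scatter) from compound 3 to compound 4; the limit leaves it open whether they differ Compound 1 gives only a limit, so the size of the earlier step stays unknown, and the data show neither that the change carries over unaltered from one core to the other nor that it does not: the limit of > 60000 nM in this assay, at which 1 of the 4 values shown sits.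

Still open, from the compounds shown here alone, is whether any other group in this place, such as a chloro group, a nitrile, an amine or a carboxylic acid, would give a step beyond the scatter on either core. Also open, going by these compounds, is how the same change would read with a longer chain in place of the ((4-fluorophenyl)carbonyl)methyl group.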